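Trifluoromethyl to Carboxyethenyl: Expected Effect on Adenosine Binding

The source may report more compounds than this note shows. Statements on the series, on what has been measured and on what is new or still open speak of the compounds shown alone.

Compound 1 `CCCn1c(=O)c2nc(C(F)(F)F)[nH]c2n(CCC)c1=O`: 4.5%
Compound 2 `Cn1c(=O)c2c(nc(C(F)(F)F)n2C)n(C)c1=O`: 8%

In an assay on membranes from brain for binding affinity to adenosine receptor A1 (Rattus norvegicus), tested at 100 uM (a lower number here means less inhibition, a higher number more inhibition at the concentration tested (going by the name of the read-out)), compound 1 gives 4.5% and compound 2 gives 8%; these two values lie within the scatter of each other, and both show little inhibition. Compound 3 `Cn1c(=O)c2c(nc(/C=C/C(=O)O)n2C)n(C)c1=O` differs from compound 2 by 2-carboxyethenyl in place of trifluoromethyl on an aromatic carbon. Going by the values given here, no measured step of this kind is available. Little inhibition is expected to remain, so the step of no change at the digits printed from compound 2 to compound 3 (within the scatter) is estimated to stay within the scatter, in no clear direction. Compound 3 is therefore expected to give about 8% in this assay, with a range from 0% to 25%.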

Compound 3, a percentage reported as inhibition, at one concentration (the size of the read-out at that concentration, not a potency): 3%
For compound 3 the middle estimate is 5 percentage points above the measured one, and the stated range covers the measured number.
By their numbers in this assay, from the lowest: compounds 3, 1 and 2 (each within the scatter of the next).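

In this assay, the exchange of trifluoromethyl for 2-carboxyethenyl on this aromatic carbon gives a number 5 percentage points lower from compound 2 to compound 3 (within the scatter), the first step measured at this position. Bringing in a hydrogen-bond donor and a hydrogen-bond acceptor here thus leaves inhibition low, with no shift beyond the scatter. Nothing available accounts for this result. Going by these compounds, whether an amine or a phenyl ring at this position would give clear inhibition remains open. Also open, on these data alone, is whether 2-carboxyethenyl would act the same way on the core of compound 1.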